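Swapping a Chloro for a Methyl on a Receptor Modulator

The compounds below may be only part of what the source reports. "The series", "measured", "known", "first", "only" and "open" are said of these compounds alone.

Compound 1, `Cc1cccc(-c2noc(C3CN(S(=O)(=O)c4cccc(C)c4)C3)n2)c1`: 650 nM
Compound 2, `O=S(=O)(c1ccc(Cl)cc1)N1CC(c2nc(-c3cccc(Cl)c3)no2)C1`: 170 nM

Of the compounds shown here, two have been tested in an assay on HEK293 cells for negative allosteric modulation of metabotropic glutamate receptor 5 (Homo sapiens), read by FLIPR; a higher number here means a weaker inhibitor, a lower number a stronger inhibitor. Compound 2 gives 170 nM, the lowest of the two numbers, while compound 1 gives 650 nM, a gap beyond the usual scatter. Compound 3 `Cc1cccc(-c2noc(C3CN(S(=O)(=O)c4ccc(Cl)cc4)C3)n2)c1` differs from compound 2 in one place: methyl in place of chloro on an aromatic carbon, so 3-chlorophenyl becomes 3-methylphenyl and everything else stays. No direct measurement of this single change exists. Compound 1 carries that same methyl and gives the higher number, yet it differs in a second place too, so only a modest move toward weaker inhibition is expected. The expected step is a 2.1-fold higher number from compound 2 to compound 3 (0.31 log units; beyond the scatter). Compound 3 is therefore estimated at 350 nM, within a range from 150 nM to 800 nM.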

Compound 3, half-maximal inhibitory concentration: 1100 nM
Estimate against measurement, compound 3: 3.1-fold (0.50 log units) below; the measured number lies above the stated range.
By their numbers in this assay, from the lowest: compound 2; then compounds 1 and 3 (each within the scatter of the next).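

In this assay, the direct swap of 3-chlorophenyl to 3-methylphenyl gives a 6.5-fold higher number from compound 2 to compound 3 (0.81 log units; beyond the scatter) and so shows that this aromatic carbon is sensitive to a change of a single heavy atom, which compound 1 and compound 2 could not show alone. With that methyl in place, putting 4-chlorophenyl for 3-methylphenyl on the sulfonyl sulfur gives a 1.7-fold higher number from compound 1 to compound 3 (0.23 log units; within the scatter) and so leaves compound 1 and compound 3 indistinguishable. Nothing measured here explains why chloro and methyl differ at this carbon.

From the compounds shown here alone, whether fluoro, methoxy or nitrile on that carbon would match chloro remains open.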